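The source may report more compounds than this note shows. Statements on the series, on what has been measured and on what is new or still open speak of the compounds shown alone.

Among the measured compounds shown here, compound 2 `CCNC(=O)N1CC1C#N` is one of only two compounds so far measured in a functional assay on RPMI-8226 cells (Homo sapiens) for inhibition; a higher number here means a weaker inhibitor, a lower number a stronger inhibitor. In this assay compound 2 gives 22000 nM. The other measured compound, compound 1 `CCCCNC(=O)N1CC1C#N`, gives 17000 nM in this assay, and the step of a 1.3-fold higher number from compound 1 to compound 2 (0.11 log units; within the scatter) shows that trimming the chain on the amide-type nitrogen from butyl down to ethyl left the number essentially where it was. Compound 3 `CNC(=O)N1CC1C#N` has not yet been measured. It differs from compound 2 by hydrogen in place of methyl on a saturated chain carbon bound to an amide-type nitrogen, the same kind of change cut one bond further out. For the measured compounds named here, the single measured step that bears on it, a 1.3-fold higher number from compound 1 to compound 2 (0.11 log units; within the scatter), stayed inside the scatter, so for compound 3 no movement beyond the scatter is expected in this assay in either direction. The expected step of a 1.1-fold higher number from compound 2 to compound 3 (0.06 log units; within the scatter) is accordingly small. Compound 3 is estimated at 25000 nM in this assay, with a range from 12000 nM to 50000 nM.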

Compound 3, half-maximal inhibitory concentration: 26000 nM
Compound 3: the middle estimate sits 1.0-fold (0.02 log units) below what was measured; the measured number falls inside the stated range.
By their numbers in this assay, from the lowest: compounds 1, 2 and 3 (each within the scatter of the next).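

Going from ethylamino to methylamino, the step of a 1.2-fold higher number from compound 2 to compound 3 (0.07 log units; within the scatter) in this assay stays within the scatter, so this second cut to the chain behaves as the first one did. The widest comparison available, the step of a 1.5-fold higher number from compound 1 to compound 3 (0.18 log units; within the scatter), also lies within the scatter, so even the full exchange of propyl for hydrogen on this saturated chain carbon does not separate the two compounds beyond it. No measurement shown here explains why these chain differences count for so little.

The compounds shown leave open whether a chain much longer than butyl would move the number beyond the scatter. They also leave open whether a different kind of group on this chain, such as an amine, a carboxylic acid or a phenyl ring, would do so.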